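The compounds below may be only part of what the source reports. "The series", "measured", "known", "first", "only" and "open" are said of these compounds alone.

In an ADME assay on microsomes (Rattus norvegicus) for metabolic stability (a lower number here means that the compound disappears faster, a higher number that the compound lasts longer), compound 1 `CC(C)(C)C(=O)N1CCSC1c1ccccc1` gives 0.0533 h as its measured half-life. Compound 2 `O=C(c1cnco1)N1CCC(C(=O)N2N=CC[C@H]2c2ccccc2)CC1` gives > 3 h in this assay, and this is a limit of the assay and not a number. Compound 2 therefore stands at the limit of > 3 h in this assay, at which 1 of the 2 values shown sits, and its true half-life remains unread.

Compound 3 `O=C(c1cscn1)N1CCC(C(=O)N2N=CC[C@H]2c2ccccc2)CC1` keeps the rest of compound 2 and changes one group on a carbonyl carbon: 1,3-thiazol-4-yl in place of 1,3-oxazol-5-yl on a carbonyl carbon is the whole difference. In words, 1,3-thiazol-4-yl takes the place of 1,3-oxazol-5-yl.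

Among the compounds with values here, no measured pair here differs in only one place, so the data offer no direct guide to the size of this swap. The two rings match in size and in the counted features, so only a modest step in this assay is expected, more likely toward a shorter half-life than a longer one, and possibly none beyond the scatter. The estimated change is an at least 1.2-fold lower number from compound 2 to compound 3 (0.07 log units; that floor lies within the scatter) in this reading. For compound 3 the expected half-life is 2.5 h with an estimated range from 1 h to 6 h in repeat measurements.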

Compound 3, half-life: 0.65 h
Compound 3: the middle estimate sits 3.8-fold (0.59 log units) above what was measured, outside the stated range (below it).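

In this assay, the group on this carbonyl carbon clearly matters: 1,3-thiazol-4-yl in place of 1,3-oxazol-5-yl gives an at least 4.6-fold lower number from compound 2 to compound 3 (0.66 log units; beyond the scatter). The two groups are alike in everything counted here, with one five-membered aromatic ring, the same number of heavy atoms, hydrogen-bond donors and acceptors, and no net charge, so those counts alone do not foretell this step. The true size of the step stays unknown because compound 2 has a limit of the assay and not a number: the limit of > 3 h in this assay, at which 1 of the 3 values shown sits.

The compounds shown leave open whether the step comes from sulfur taking the place of oxygen or from the different way the ring is attached, as the two group names differ in both respects, and one pair cannot separate these two changes. They also leave open how a group outside this pair of five-membered rings, such as a plain phenyl group or a pyridine ring, would behave on the same carbonyl carbon, and whether this step would recur on a different core.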